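Hydroxy to methoxy on compound 1

This account rests on a few compounds, and the source may have more. Where it says the series, first, only, none or still open, it means among the compounds named here.

Measured in a functional assay on MCF7 cells (Homo sapiens) for inhibition (a lower number here means a stronger inhibitor, a higher number a weaker inhibitor), so far:
- compound 1 `Oc1ccc(-c2nc3cc(F)ccc3s2)cc1` gives 400 nM
- compound 2 `Oc1ccc(-c2nc3cc(C(F)(F)F)ccc3s2)cc1` gives 13800 nM
- compound 3 `COc1ccc(-c2nc3ccc(F)cc3o2)cc1` gives 41000 nM

Compound 1 has the lowest number of the three and is the strongest inhibitor measured so far. The next structure, compound 4 `COc1ccc(-c2nc3cc(F)ccc3s2)cc1`, differs from it by one change: methyl in place of hydrogen on an oxygen on an aromatic ring, which reads as hydroxy to methoxy.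

Going by the values given here, no measured step covers this change. Among the compounds with values here, the only step, a 35-fold higher number from compound 1 to compound 2 (1.54 log units; beyond the scatter), swaps fluoro for trifluoromethyl on an aromatic carbon, elsewhere on the molecule. It shows only that this series can respond sharply to a small edit in this assay. Within the data shown here, compound 3 is the only measured methoxy compound and gives 41000 nM, but its core differs from that of compound 4, so it is weak evidence on direction. A moderate move towards weaker inhibition is therefore expected, with wide uncertainty, and the estimated change is a 6.3-fold higher number from compound 1 to compound 4 (0.80 log units; beyond the scatter). The estimate for compound 4 is 2500 nM, with an expected range of 200 nM to 25000 nM.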

Compound 4, half-maximal inhibitory concentration: 490 nM
Beside the measured number, compound 4's estimate is 5.1-fold (0.71 log units) above it; measured number inside the range.
By their numbers in this assay, from the lowest: compounds 1 and 4 (each within the scatter of the next); then compound 2; then compound 3.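

Replacing hydroxy with methoxy on the core of compound 1 has no effect that stands out from repeat measurements in this assay (a 1.2-fold higher number from compound 1 to compound 4 (0.09 log units; within the scatter)). A free hydroxy at this oxygen on an aromatic ring is therefore not needed for the activity seen with compound 1, and the series does not respond sharply to every small edit, unlike the change of fluoro to trifluoromethyl (a 35-fold higher number from compound 1 to compound 2 (1.54 log units; beyond the scatter)). Nothing available explains why methyl is tolerated at this oxygen.

The compounds shown leave open whether this tolerance extends beyond methyl, for example to a longer chain on the oxygen or to an amine in place of the hydroxy. They also leave open whether the same change would read the same way with trifluoromethyl in place of fluoro, as in compound 2.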